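The compounds below may be only part of what the source reports. "The series", "measured", "known", "first", "only" and "open" are said of these compounds alone.

The measured compounds:

Compound 1, `COc1nc(C2CCOCC2)ccc1[C@@H](c1ccccc1)[C@@](O)(CCN(C)C)c1cccc2ccccc12`, gives in a toxicity assay on Vero cells (Chlorocebus sabaeus) for cytotoxicity (a lower number here means that less compound is tolerated, a higher number that more compound is tolerated), a result of > 50 ug/mL.
Compound 2, `COc1ncc(-c2ccccc2)cc1[C@@H](c1ccccc1)[C@@](O)(CCN(C)C)c1ccccc1`, gives in this assay a result of > 50 ug/mL.
Compound 3, `COc1nc(-c2cnsc2)ccc1[C@@H](c1ccccc1)[C@@](O)(CCN(C)C)c1cccc2ccccc12`, gives in this assay a result of 26.3 ug/mL.

The result for compound 2 in this assay is a limit of the assay, not a number. Compound 2 therefore stands at the limit of > 50 ug/mL in this assay, at which 2 of the 3 values shown sit, and so its exact tolerance is not known. Going by the values given here, the one step between measured compounds that differ in a single place is an at least 1.9-fold lower number from compound 1 to compound 3 (0.27 log units; that floor lies within the scatter), with compound 3 standing at a number below the limit. That step changes a group on an aromatic carbon of the shared core, whereas the change to compound 4 lies elsewhere.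

Compound 4, `COc1ncc(-c2ccccc2)cc1[C@@H](c1ccccc1)[C@@](O)(CCN(C)C)c1cccc(F)c1F`, has not yet been tested in this assay. It differs from compound 2 in this way: 2,3-difluorophenyl in place of phenyl on a saturated chain carbon bound to an oxygen on a saturated carbon and two saturated chain carbons. Among the compounds with values here, no measured step concerns this place or this pair of groups, so nothing from the data argues for a movement beyond the scatter. With compound 2 sitting at a limit, the change from compound 2 to compound 4 is expected to give a number no higher from compound 2 to compound 4 (the limit leaves the size open), that is, no clear shift. The estimate for compound 4 in this assay is 50 ug/mL, within a range of 25 ug/mL to 100 ug/mL, with a fair chance that only a limit is reported again.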

Compound 4, half-maximal cytotoxic concentration: > 50 ug/mL
Compound 4: no number, only a limit; the forecaster's own chance of this, stated with the estimate: 60%; the middle value lies on the limit itself.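

In this assay compound 4 gives > 50 ug/mL, which is a limit of the assay and not a number. Compound 2 also stands at a limit, so no step from compound 2 to compound 4 can be read: the limit of > 50 ug/mL in this assay, at which 3 of the 4 values shown sit.

The compounds shown leave open how much of compound 2 or compound 4 is tolerated, and whether 2,3-difluorophenyl in place of phenyl changes that at all.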